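Isopropyl in place of chloro on an aromatic carbon

The source may hold more compounds than are shown below. What is called first, only, known or untested is meant among the compounds shown, and "the series" means these compounds.

Of the compounds shown here, two sharing one core have been measured so far in a functional assay on HCT-116 cells (Homo sapiens) for antiproliferative activity, read by MTT assay, with a stated time of 48 h; a lower number here means a stronger inhibitor, a higher number a weaker inhibitor. Compound 1 `O=C(/C=C/c1ccc(/C=C/C(=O)c2ccccc2)o1)NO` gives 2890 nM, and compound 2 `O=C(/C=C/c1ccc(/C=C/C(=O)c2ccc(Cl)cc2)o1)NO`, which carries a chloro group, gives 2010 nM. These two numbers lie within the usual scatter of each other, so compound 2 cannot yet be told apart from compound 1. The next compound is compound 3 `CC(C)c1ccc(C(=O)/C=C/c2ccc(/C=C/C(=O)NO)o2)cc1`, with isopropyl in place of chloro on an aromatic carbon, para to a large group: isopropyl in place of chloro on an aromatic carbon. Among the measured compounds shown here, only one measured step bears on this place: a 1.4-fold lower number from compound 1 to compound 2 (0.16 log units; within the scatter), with chloro in place of hydrogen on an aromatic carbon. That step stays within the scatter. For the measured compounds named here, no compound with isopropyl has been measured, so the data offer no direction for this change, and no step beyond the scatter is expected in this assay. The expected step is a 1.1-fold higher number from compound 2 to compound 3 (0.06 log units; within the scatter), which would be no clear change. Compound 3 is estimated at 2300 nM, with an expected range of 900 nM to 5500 nM.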

Compound 3, half-maximal inhibitory concentration: 490 nM
The estimate for compound 3 lay 4.7-fold (0.67 log units) above the measured number, and the stated range ends above it.
By their numbers in this assay, from the lowest: compound 3; then compounds 2 and 1 (each within the scatter of the next).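

In this assay this place on the six-membered aromatic ring proves able to respond to the group it carries, since a 4.1-fold lower number from compound 2 to compound 3 (0.61 log units; beyond the scatter) and a 5.9-fold lower number from compound 1 to compound 3 (0.77 log units; beyond the scatter) are both beyond the scatter, whereas the earlier change from hydrogen to chloro stayed within it. Compound 3 therefore stands as the strongest inhibitor of the three, and isopropyl, with three heavy atoms, can be told apart here from both chloro and hydrogen. Nothing given here accounts for why isopropyl lowers the number when chloro does not.

With only hydrogen, chloro and isopropyl shown at this place, one cannot say whether the lower number belongs to isopropyl alone or would also appear with other carbon groups such as methyl or tert-butyl, or with a group of a different kind such as methoxy or an amine. As far as these compounds go, it also stays open whether isopropyl would give a similar step at another place on this ring, or on a compound with a different core.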